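Trimming the Amide Tail of a Cholesterol Transporter Binder

The compounds below may be only part of what the source reports. "The series", "measured", "known", "first", "only" and "open" are said of these compounds alone.

Compound 1 `COC(=O)CCCNC(=O)CN1CN(c2ccccc2)C2(CCN(C(=O)c3ccc(C4CCCCC4)cc3)CC2)C1=O` was tested in an assay on HEK293 cells for displacement of a labelled ligand from NPC1-like intracellular cholesterol transporter 1 (Homo sapiens) (a higher number here means a weaker inhibitor, a lower number a stronger inhibitor), and gave 2500 nM. A companion, compound 2 `CCc1nn(CC)c(C2CCN(C(=O)CN3CN(c4ccccc4)C4(CCN(C(=O)c5ccc(C(C)(C)C)cc5)CC4)C3=O)CC2)c1C`, carries a different partner on the amide and a different group on the benzoyl ring; in this assay compound 2 gives 2500 nM. Compound 1 therefore stands level with compound 2 at the digits recorded, and the two readings lie within the usual scatter of each other, so neither can be called the stronger binder.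

The next compound, compound 3 `O=C(CN1CN(c2ccccc2)C2(CCN(C(=O)c3ccc(C4CCCCC4)cc3)CC2)C1=O)NCO`, keeps the shared core of compound 1 and alters only the tail on the amide nitrogen: hydroxy in place of 2-(methoxycarbonyl)ethyl on a saturated chain carbon bound to an amide-type nitrogen.

Within the data shown here, no measured pair covers a change of this kind, so the expectation rests on the two values at hand, which show that a considerable alteration elsewhere in the molecule left the reading unchanged. The expected step is a 1.2-fold higher number from compound 1 to compound 3 (0.08 log units; within the scatter), that is, small and in no clear direction beyond the scatter. Compound 3 is estimated at 3000 nM in this assay, with a likely range from 1000 nM to 9000 nM.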

Compound 3, half-maximal inhibitory concentration: 8300 nM
Compound 3: middle estimate off by 2.8-fold (0.44 log units), on the low side; the range from low to high includes it.
By their numbers in this assay, from the lowest: compounds 1 and 2 (each within the scatter of the next); then compound 3.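

Among these compounds, compound 1 and compound 3 differ in one place only, so this is the first reading of the amide tail on its own: in this assay, putting hydroxy in place of 2-(methoxycarbonyl)ethyl gives a 3.3-fold higher number from compound 1 to compound 3 (0.52 log units; beyond the scatter). A higher number means a weaker inhibitor here, so this position on a saturated chain carbon bound to an amide-type nitrogen does respond to what sits on it, although the step is modest. Nothing measured here accounts for the step.

The change removes the methoxycarbonyl group and shortens the tail while also bringing in the hydroxy, so these two compounds cannot show which of those parts moves the number. On these data alone, it remains open whether a plain propyl chain, or a carboxylic acid in place of the methoxycarbonyl end of the 3-(methoxycarbonyl)propyl tail, would read closer to compound 1 or to compound 3.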